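A few compounds are considered here, and "the series" means these few. Any claim that something is new, unique, unknown or untested is made for them only; others in the source may bear on it.

Measured so far in an assay on LtK cells with ATP-sensitive inward rectifier potassium channel 11 (Homo sapiens) as the target; on this read-out lower numbers stand for an effect already at smaller amounts and higher numbers for an effect only at larger amounts of compound:
compound 1 `CC(C)CCC(=O)Nc1c(C(O)(C(F)(F)F)C(F)(F)F)ccc2ccccc12` gives 49 nM
compound 2 `CC(C)OC(=O)Nc1c(C(O)(C(F)(F)F)C(F)(F)F)ccc2ccccc12` gives 1160 nM

Compound 2 stands highest of the two numbers in this assay, set apart from compound 1 by the step of a 24-fold higher number from compound 1 to compound 2 (1.37 log units; beyond the scatter), a large step well beyond the usual scatter. Compound 3 `Cc1ccccc1C(=O)Nc1c(C(O)(C(F)(F)F)C(F)(F)F)ccc2ccccc12` has not yet been measured. It differs from compound 2 by 2-methylphenyl in place of isopropoxy on a carbonyl carbon. For the measured compounds named here, only one measured step bears on this change, namely a 24-fold higher number from compound 1 to compound 2 (1.37 log units; beyond the scatter), where isopropoxy replaced isopentyl on the carbonyl carbon and the number climbed steeply. Compound 3 reverses that kind of change: a carbon group, here 2-methylphenyl, returns to the carbonyl carbon in place of isopropoxy. Going by the values given here, it is a ring rather than a chain, and no measured pair shows what an aromatic ring does in that position, so the margin is wide. The expected step for compound 3 is a 12-fold lower number from compound 2 to compound 3 (1.06 log units; beyond the scatter), a clear fall in the number back toward the level of compound 1. For compound 3 the estimate in this assay is 100 nM, within 25 nM to 400 nM.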

Compound 3, half-maximal effective concentration: 5550 nM
Estimate against measurement, compound 3: 56-fold (1.74 log units) below; the measured number lies above the stated range.
By their numbers in this assay, from the lowest: compound 1; then compound 2; then compound 3.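

In this assay the numbers do not divide simply into carbon groups on one side and isopropoxy on the other. 2-methylphenyl in place of isopropoxy gives a 4.8-fold higher number from compound 2 to compound 3 (0.68 log units; beyond the scatter) and so does not bring the number back toward that of compound 1. The same ring in place of isopentyl gives a 110-fold higher number from compound 1 to compound 3 (2.05 log units; beyond the scatter) as the widest gap among the three compounds, which shows that a carbon atom on the carbonyl is not enough to keep the number low, since compound 1 with its open chain has the lowest number and compound 3 with its ring the highest. No measurement at hand explains this order.

As far as these compounds go, it stays open whether the higher number of compound 3 belongs to the aromatic ring as such or to its methyl group, a question that plain phenyl in the same place would address. Also open, from the compounds shown here alone, is how far the low number of compound 1 depends on the length and branching of isopentyl, which a shorter chain such as propyl or a longer one such as octyl would test.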